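Fluoro in Place of Methyl: From Compound 3 to Compound 4

The compounds below may be only part of what the source reports. "The series", "measured", "known", "first", "only" and "open" are said of these compounds alone.

Measured in a functional assay on HT-29 cells (Homo sapiens) for antiproliferative activity, read by sulforhodamine B assay, with a stated time of 72 h; on this read-out lower numbers stand for stronger inhibition and higher numbers for weaker inhibition:
Compound 1 `NC(=S)N/N=C/c1ccc2ccccc2n1` gives 100000 nM.
Compound 2 `Fc1cccc(NC(=S)N/N=C/c2ccc3ccccc3n2)c1` gives 74700 nM.
Compound 3 `Cc1ccccc1NC(=S)N/N=C/c1ccc2ccccc2n1` gives 42300 nM.

Compound 3 has the lowest number of the three: its step from compound 1 is a 2.4-fold lower number from compound 1 to compound 3 (0.37 log units; beyond the scatter), while the step from compound 2 is a 1.8-fold lower number from compound 2 to compound 3 (0.25 log units; within the scatter), within the scatter. Compound 4 `Fc1ccccc1NC(=S)N/N=C/c1ccc2ccccc2n1` differs from compound 3 by fluoro in place of methyl on an aromatic carbon. Within the data shown here, no measured step swaps these two groups at the same place. The nearest comparison, a 1.8-fold lower number from compound 2 to compound 3 (0.25 log units; within the scatter), changes both group and place and stays within the scatter, and a 1.3-fold lower number from compound 1 to compound 2 (0.13 log units; within the scatter) shows that adding a fluorophenyl group barely moved the number. A step no larger than the scatter is therefore expected in this assay, a 1.3-fold higher number from compound 3 to compound 4 (0.11 log units; within the scatter). Compound 4 is estimated at 55000 nM, with a range from 25000 nM to 120000 nM.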

Compound 4, half-maximal inhibitory concentration: > 100000 nM
Compound 4 ended at the assay's limit; the forecaster's own chance of this, stated with the estimate: 15%; at least 1.8-fold (0.25 log units) between middle value and limit.
By their numbers in this assay, from the lowest: compounds 3, 2 and 1 (each within the scatter of the next, the first and the last beyond it).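

Fluoro in place of methyl on an aromatic carbon, ortho to a large group, gives an at least 2.3-fold higher number from compound 3 to compound 4 (0.37 log units; beyond the scatter) in this assay and so moves the number beyond the scatter at this one place, which no earlier step between two aryl groups did. Compound 4 carries a limit and not a number: the limit of > 100000 nM in this assay, at which 1 of the 4 values shown sits. Against the 3-fluorophenyl group, the 2-fluorophenyl group gives an at least 1.3-fold higher number from compound 2 to compound 4 (0.12 log units; that floor lies within the scatter) and sets no order, and against hydrogen it gives a number no lower from compound 1 to compound 4 (the limit leaves the size open), a step whose size cannot be read. The compounds shown leave open how chloro, methoxy or ethyl would read at this place, and whether methyl would keep its number at the other ring positions.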